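A few compounds are considered here, and "the series" means these few. Any claim that something is new, unique, unknown or untested is made for them only; others in the source may bear on it.

In a functional assay on cells (Leukemia cell, Homo sapiens) for inhibition, with a stated time of 48 h (on this read-out lower numbers stand for stronger inhibition of growth and higher numbers for weaker inhibition of growth), compound 1 (`COc1cc2c(/C=C3/C(=O)Nc4cc(Cl)ccc43)c(Cl)n(C)c2cc1C`) gives 1740 nM as its number, compound 2 (`CN(C)c1ccc2[nH]c(Cl)c(/C=C3/C(=O)Nc4ccc(O)cc43)c2c1`) gives 13500 nM and compound 3 (`COc1cc2c(/C=C3/C(=O)N(C)c4ccccc43)c[nH]c2cc1C`) gives 35500 nM as the highest of the three, beyond the scatter from both others. Compound 4 (`COc1cc2c(/C=C3/C(=O)N(C)c4ccc(O)cc43)c[nH]c2cc1C`) differs from compound 3 by one change (hydroxy in place of hydrogen on an aromatic carbon): hydroxy in place of hydrogen on an aromatic carbon. Among the compounds with values here, no measured pair isolates this change. Compound 2 also bears a hydroxy and gives 13500 nM with other substituents around it, which is weak support only. A modest move toward stronger inhibition of growth is expected, about the edge of the scatter: the estimated step is a 2.2-fold lower number from compound 3 to compound 4 (0.35 log units; beyond the scatter) in this assay here. For compound 4 the expected value is 16000 nM with an estimated range from 5500 nM to 42000 nM on this read-out.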

Compound 4, concentration for total growth inhibition: 36300 nM
Beside the measured number, compound 4's estimate is 2.3-fold (0.36 log units) below it; the range from low to high includes it.
By their numbers in this assay, from the lowest: compound 1; then compound 2; then compounds 3 and 4 (each within the scatter of the next).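

In this assay the hydroxy in place of hydrogen is now isolated as a single change, and the step is a 1.0-fold higher number from compound 3 to compound 4 (0.01 log units; within the scatter). On this aromatic carbon, meta to a fused ring and para to a fused ring, adding the hydroxy to compound 3 therefore brings no change beyond the scatter. No supporting data are available to explain this result.

Going by these compounds, whether an amine or a carboxylic acid on this carbon would shift the number remains open. So does whether the hydroxy would read the same on the core of compound 1, which carries other substituents.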